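The source may report more compounds than this note shows. Statements on the series, on what has been measured and on what is new or still open speak of the compounds shown alone.

Compound 1, `CCCCCCCCCCCCCCCCNC(=O)C1CCCC1`, is the simplest member of this small set. In an assay on HEK293 cells for inhibition of N-acylethanolamine-hydrolyzing acid amidase (Homo sapiens), read by scintillation counting, tested at 50 uM (on this read-out higher numbers stand for more inhibition at the one concentration tested (going by the name of the read-out) and lower numbers for less inhibition), compound 1 gives 8%. Compound 2, `CCCCCCCCCCCCCCCCNC(=O)c1ccc([N+](=O)[O-])cc1`, differs from it by 4-nitrophenyl in place of cyclopentyl on a carbonyl carbon; in this assay compound 2 gives 4%, so the step is a number 4 percentage points lower from compound 1 to compound 2 (within the scatter). Compound 3, `CCCCCCCCCCCCCCCCOC(=O)C1CCCC1`, differs from compound 1 by (cyclopentylcarbonyl)oxy in place of (cyclopentylcarbonyl)amino on a saturated chain carbon bound to a saturated chain carbon; in this assay compound 3 gives 17%, a step of a number 9 percentage points higher from compound 1 to compound 3 (within the scatter). Compound 2 and compound 3 differ in two places, and their difference is not broken down here; their two values simply stand apart by more than the usual scatter.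

Compound 4, `CCCCCCCCCCCCCCCCOC(=O)c1ccc([N+](=O)[O-])cc1`, has not yet been measured. It differs from compound 3 by 4-nitrophenyl in place of cyclopentyl on a carbonyl carbon. This is the same kind of change as that between compound 1 and compound 2, though not the same: around the place, the carbonyl carbon's other neighbour is an oxygen next to a carbonyl group in compound 3, whereas in compound 1 it is an amide-type nitrogen. Because the earlier step was a number 4 percentage points lower from compound 1 to compound 2 (within the scatter), compound 4 is expected to move by a number 5 percentage points lower from compound 3 to compound 4 (within the scatter). Compound 4 is therefore estimated to give 12%, most likely between 2% and 25%.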

Compound 4, a percentage reported as inhibition, at one concentration (the size of the read-out at that concentration, not a potency): 26%
For compound 4 the middle estimate is 14 percentage points below the measured one; measured number above the stated range.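

Putting 4-nitrophenyl in place of cyclopentyl on a carbonyl carbon gives, in this assay, a number 9 percentage points higher from compound 3 to compound 4 (within the scatter). Set beside the earlier step on the other core, the same change does not read differently by more than the scatter allows: the same change on two cores in this assay, a number 4 percentage points lower (within the scatter) from compound 1 to compound 2 and a number 9 percentage points higher (within the scatter) from compound 3 to compound 4, 13 percentage points apart, within the scatter of two such steps

This shows no disagreement between the two cores, and nothing here stands against carrying the change from one to the other. It does not show that the change has a real effect on either core, or that its size is the same on both, as each step lies within the scatter and two steps are too few to support a rule for the series.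

The compounds shown leave open whether a plain phenyl or a cyclohexyl on the carbonyl carbon would read alike on both cores. They also leave open what an amine in place of the nitro group of the 4-nitrophenyl, or a shorter chain on either core, would do to the numbers.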